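Swapping methoxy for chloro on a weakly active amide

A few compounds are considered here, and "the series" means these few. Any claim that something is new, unique, unknown or untested is made for them only; others in the source may bear on it.

Measured compounds:
compound 1 `O=C(Nc1ccc(Oc2ccnc3[nH]ccc23)cc1)c1ccc(-c2ccc(Cl)cc2)cn1` gives > 10000 nM
compound 2 `Cc1ccc(-c2ccnc(C(=O)Nc3ccc(Oc4ccnc5[nH]ccc45)cc3)c2)cc1` gives > 10000 nM
compound 3 `COc1ccc(-c2ccnc(C(=O)Nc3ccc(Oc4ccnc5[nH]ccc45)cc3)c2)cc1` gives 9620 nM

In a functional assay on PC-3 cells (Homo sapiens) for cytotoxicity, read by MTT assay, with a stated time of 72 h (a higher number here means a weaker inhibitor, a lower number a stronger inhibitor), compound 1 reaches only a limit of the assay, > 10000 nM. Compound 2 likewise reaches only a limit, > 10000 nM. For the measured compounds named here, compound 3 is the one compound here with a number, 9620 nM, so it stands as the sole measured point among the three.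

Compound 4 `O=C(Nc1ccc(Oc2ccnc3[nH]ccc23)cc1)c1cc(-c2ccc(Cl)cc2)ccn1` is not yet measured. It differs from compound 3 in one place: chloro in place of methoxy on an aromatic carbon. Going by the values given here, the only measured step that touches this part of the molecule is an at least 1.0-fold lower number from compound 2 to compound 3 (0.01 log units; that floor lies within the scatter), a change too small to count. Both neighbours of compound 3 on this side of the structure sit at the limit of > 10000 nM in this assay, at which 2 of the 3 values shown sit. A further swap at the same place is therefore expected to give a step of about a 1.2-fold higher number from compound 3 to compound 4 (0.10 log units; within the scatter) in this assay, which is no real change. Compound 4 is estimated at 12000 nM, with a range from 5000 nM to 30000 nM, and a good chance that only a limit is reported.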

Compound 4, half-maximal inhibitory concentration: 25100 nM
Compound 4: the middle estimate sits 2.1-fold (0.32 log units) below what was measured, within the range that was stated.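

In this assay, the para position of this outer phenyl ring now shows a change beyond the scatter, which the earlier methyl-to-methoxy step could not show: a 2.6-fold higher number from compound 3 to compound 4 (0.42 log units; beyond the scatter). Going from 4-methoxyphenyl to 4-chlorophenyl therefore costs a modest amount of activity, and compound 3 keeps the edge over compound 4. The step from compound 2 to compound 4 cannot be read, and compound 2 stands at a limit of the assay: the limit of > 10000 nM in this assay, at which 2 of the 4 values shown sit.

The compounds shown do not tell why chloro falls behind methoxy, and both compounds remain weak in this assay. As far as these compounds go, it also stays open whether an amine, a carboxylic acid or a longer chain such as ethoxy at this same place would move the number further in either direction.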